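Lengthening the Methoxy Group of Compound 2

The source may hold more compounds than are shown below. What is called first, only, known or untested is meant among the compounds shown, and "the series" means these compounds.

Among the compounds with values here, in a functional assay on LoVo cells (Homo sapiens) for inhibition, read by colorimetric assay and MTT assay, with a stated time of 72 h (on this read-out higher numbers stand for weaker inhibition and lower numbers for stronger inhibition), compound 2 (`COc1ccccc1-c1cnc(OC)n1C`) gives 73000 nM as the higher of the two numbers so far, and compound 1 (`CCCCCCOc1ncc(-c2ccccc2OC)n1C`) gives 27000 nM as the lower. Compound 3 (`C=CCCOc1ncc(-c2ccccc2OC)n1C`) has not yet been measured. Its change from compound 2 (allyl in place of hydrogen on a saturated chain carbon bound to an oxygen on an aromatic ring) puts allyl in place of hydrogen on a saturated chain carbon bound to an oxygen on an aromatic ring. Within the data shown here, the only measured step that bears on this is a 2.7-fold higher number from compound 1 to compound 2 (0.43 log units; beyond the scatter) on going from pentyl to hydrogen at that place. Among the measured compounds shown here, compound 3 moves the opposite way with the smaller allyl, and its double bond is untested, so a modest move to a lower number is expected in this assay and no larger than that step. The expected change is a 1.6-fold lower number from compound 2 to compound 3 (0.21 log units; within the scatter) as estimated from that single step. Compound 3 is expected at 45000 nM (range 24000 nM to 85000 nM).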

Compound 3, half-maximal inhibitory concentration: 24000 nM
The estimate for compound 3 lay 1.9-fold (0.27 log units) above the measured number, and the stated range covers the measured number.
By their numbers in this assay, from the lowest: compounds 3 and 1 (each within the scatter of the next); then compound 2.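

In this assay, the step of a 3.0-fold lower number from compound 2 to compound 3 (0.48 log units; beyond the scatter) lies beyond the scatter, so a second, different chain in place of the methoxy group also gives a lower number, and the effect of replacing that group is not confined to the chain of compound 1. With vinyl in place of butyl on a saturated chain carbon, two bonds along the chain from an oxygen on an aromatic ring, the step of a 1.1-fold lower number from compound 1 to compound 3 (0.05 log units; within the scatter) lies within the scatter, so this assay does not tell those two chains apart. Nothing in the data shown speaks to what lies behind these numbers.

On these data alone, it remains open whether a longer chain, or a chain ending in an amine or a carboxylic acid, would shift the number further. As far as these compounds go, it is also open how a saturated butyl chain on that oxygen would compare with compound 3, which would speak to the double bond.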